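Chalcone-pyrazole series: notes on the carbonyl-side aryl

The source may report more compounds than this note shows. Statements on the series, on what has been measured and on what is new or still open speak of the compounds shown alone.

Measured compounds:
compound 1 `COc1ccc(-c2cc(/C=C/C(=O)c3ccc(N)cc3)[nH]n2)cc1` — 2860 nM
compound 2 `COc1cc(-c2cc(/C=C/C(=O)c3ccc(N)cc3)[nH]n2)cc(OC)c1OC` — 3800 nM
compound 3 `COc1ccc(C(=O)/C=C/c2cc(-c3cc(OC)c(OC)c(OC)c3)n[nH]2)cc1` — 2700 nM

In a functional assay on NCI/ADR-RES cells (Homo sapiens) for inhibition, read by sulforhodamine B assay, with a stated time of 48 h (a lower number here means a stronger inhibitor of growth, a higher number a weaker inhibitor of growth), compound 2 gives 3800 nM. Compound 1 gives 2860 nM and compound 3 gives 2700 nM; all three numbers lie within the usual scatter of one another, so no ordering among them is supported.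

Compound 4 `COc1cc(-c2cc(/C=C/C(=O)c3ccc(F)c(F)c3)[nH]n2)cc(OC)c1OC` is not yet measured. Relative to compound 2 it carries 3,4-difluorophenyl in place of 4-aminophenyl on a carbonyl carbon. For the measured compounds named here, the one measured step that touches the same aryl is the exchange of the amino group on compound 2 for methoxy, which gave a 1.4-fold lower number from compound 2 to compound 3 (0.15 log units; within the scatter). That step removed the hydrogen-bond donor and left the number essentially unchanged. The change to compound 4 also removes the donor and the acceptor, and the two fluorines introduce nothing for which a measured step exists. No step beyond the scatter is therefore expected in this assay; a step of a 1.2-fold lower number from compound 2 to compound 4 (0.07 log units; within the scatter) is estimated. Compound 4 is expected to give 3200 nM, with a range of 1200 nM to 8500 nM.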

Compound 4, concentration for 50% growth inhibition: 3460 nM
The estimate for compound 4 lay 1.1-fold (0.03 log units) below the measured number, and the stated range covers the measured number.
By their numbers in this assay, from the lowest: compounds 3, 1, 4 and 2 (each within the scatter of the next).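

In this assay the 3,4-difluorophenyl group on a carbonyl carbon gives a 1.1-fold lower number from compound 2 to compound 4 (0.04 log units; within the scatter) and a 1.3-fold higher number from compound 3 to compound 4 (0.11 log units; within the scatter) so its number stands level with those of both 4-aminophenyl and 4-methoxyphenyl. The earlier step had covered only the exchange of amino for methoxy; this position now also accepts an aryl with 0 hydrogen-bond donors and 0 hydrogen-bond acceptors, and with two fluorines in place of either group, without a step beyond the scatter. Nothing available bears on why these numbers sit together.

With all three groups level, the compounds shown give no ordering at this position and no group here that moves the number beyond the scatter. Going by these compounds, whether a carboxylic acid or a dimethylamino group on this aryl, or a pyridine ring in its place, would do so remains open.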